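This account rests on a few compounds, and the source may have more. Where it says the series, first, only, none or still open, it means among the compounds named here.

Measured in a functional assay on HCT-116 cells (Homo sapiens) for antiproliferative activity, read by MTT assay, with a stated time of 48 h; on this read-out higher numbers stand for weaker inhibition and lower numbers for stronger inhibition:
- compound 1 `COc1ccc(N(C)c2cc(C)nc(C)n2)cc1`: 1320 nM
- compound 2 `COc1ccc(N(C)c2cc(C)nc(C)n2)cc1Cl`: 1190 nM
- compound 3 `COc1ccc(N(C)c2cc(C)nc(C)n2)cc1[N+](=O)[O-]`: 4670 nM

Compound 1 stands level with compound 2: a 1.1-fold lower number from compound 1 to compound 2 (0.05 log units; within the scatter). The nitro steps go upward: a 3.5-fold higher number from compound 1 to compound 3 (0.55 log units; beyond the scatter), and a 3.9-fold higher number from compound 2 to compound 3 (0.59 log units; beyond the scatter).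

Next is compound 4 `Cc1cc(N(C)c2ccc([Se]C#N)cc2)nc(C)n1`, with this change: a group of 3 heavy atoms (1 carbon, 1 nitrogen, 1 selenium; no ring) in place of a group of 2 heavy atoms (1 carbon, 1 oxygen; no ring), on an aromatic carbon. For the measured compounds named here, no measured step replaces the methoxy. The chloro and nitro steps all keep it, so they bear only loosely, and the largest is modest. Going by these compounds, no step beyond the scatter is therefore expected in this assay, and the direction stays open. The expected step is a 1.3-fold lower number from compound 1 to compound 4 (0.12 log units; within the scatter). For compound 4 the estimated value is 1000 nM, with an expected range of 200 nM to 5000 nM.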

Compound 4, half-maximal inhibitory concentration: 245 nM
For compound 4 the middle estimate is 4.1-fold (0.61 log units) above the measured one, within the range that was stated.
By their numbers in this assay, from the lowest: compound 4; then compounds 2 and 1 (each within the scatter of the next); then compound 3.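

For the compounds shown here, the place para to a large group, held by the methoxy in all the earlier compounds, proves open to change: in this assay the group of 3 heavy atoms (1 carbon, 1 nitrogen, 1 selenium) gives a 5.4-fold lower number from compound 1 to compound 4 (0.73 log units; beyond the scatter) as the only downward step beyond the scatter. The chloro and nitro steps, which kept the methoxy, did not reveal this. Nothing measured here accounts for the step.

The compounds shown do not separate the selenium from the triple bond. A nitrile, a thiocyanate or a methylselenyl group on the same carbon would do so.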